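A few compounds are considered here, and "the series" means these few. Any claim that something is new, unique, unknown or untested is made for them only; others in the source may bear on it.

Of the compounds shown here, three have been measured in an assay on microsomes from intestinal mucosa for inhibition of acyl-CoA:cholesterol acyltransferase (Oryctolagus cuniculus); a lower number here means a stronger inhibitor, a higher number a weaker inhibitor. Compound 1 `CCCCCCCCCCCCCCCCCCOC(=O)Nc1c(OC)cc(OC)cc1OC` gives 7100 nM. Compound 2 `CCCCCCCC/C=C\CCCCCCCCOC(=O)Nc1c(OC)cc(OC)cc1OC` gives 860 nM. Compound 3 `CCCCCCCC/C=C\CCCCCCCCNC(=O)Nc1c(C)cccc1Cl` gives 180 nM, the lowest number of the three. Compound 1 differs from compound 2 by decyl in place of dec-1-en-1-yl on a saturated chain carbon, eight bonds along the chain from an oxygen next to a carbonyl group, and that change brought an 8.3-fold higher number from compound 2 to compound 1 (0.92 log units; beyond the scatter). The difference between the core of compound 2 and the core of compound 3 is not broken down here. Compound 4 `CCCCCCCCCCCCCCCCCCNC(=O)Nc1c(C)cccc1Cl` has not yet been measured. It differs from compound 3 by decyl in place of dec-1-en-1-yl on a saturated chain carbon, eight bonds along the chain from an amide-type nitrogen, the same kind of change as from compound 2 to compound 1, though here the chain runs from an amide-type nitrogen rather than from an oxygen next to a carbonyl group. Because the same kind of change gave an 8.3-fold higher number from compound 2 to compound 1 (0.92 log units; beyond the scatter), compound 4 is expected to show an 8.3-fold higher number from compound 3 to compound 4 (0.92 log units; beyond the scatter). Compound 4 is therefore estimated at 1500 nM, between 500 nM and 4500 nM.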

Compound 4, half-maximal inhibitory concentration: 1100 nM
The estimate for compound 4 lay 1.4-fold (0.13 log units) above the measured number; measured number inside the range.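

In this assay, putting decyl in place of dec-1-en-1-yl gave a 6.1-fold higher number from compound 3 to compound 4 (0.79 log units; beyond the scatter) on the core of compound 3. The change therefore carried over between these two cores with much the same size: the same change on two cores in this assay, an 8.3-fold higher number (0.92 log units; beyond the scatter) from compound 2 to compound 1 and a 6.1-fold higher number (0.79 log units; beyond the scatter) from compound 3 to compound 4, 1.4-fold (0.13 log units) apart, within the scatter of two such steps. Among these compounds, this rests on only two pairs of compounds, so it does not show that the change would behave the same way on any other core, and it does not explain why the double bond matters.

From the compounds shown here alone, what stays open is how a shorter chain, a longer chain, or a chain ending in an amine or a carboxylic acid would compare with decyl and dec-1-en-1-yl on these cores.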